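Three inert compounds and a chlorophenyl variant still to test

This account rests on a few compounds, and the source may have more. Where it says the series, first, only, none or still open, it means among the compounds named here.

Compound 1 `Cn1cc(C2=C(c3n[nH]c4ncccc34)C(=O)N(c3cccc4ccccc34)C2=O)c2ccccc21` gives > 100000 nM in a functional assay on A549 cells (Homo sapiens) for antiproliferative activity, read by MTT assay, with a stated time of 48 h (a lower number here means a stronger inhibitor, a higher number a weaker inhibitor), which is a limit of the assay.
Compound 2 `Cn1cc(C2=C(c3nn(CCCn4cccc4)c4ncccc34)C(=O)N(c3ccccc3)C2=O)c2ccccc21` gives > 100000 nM in this assay, also a limit.
Compound 3 `Cn1cc(C2=C(c3nn(CCCN4CCCCC4)c4ncccc34)C(=O)N(c3ccccn3)C2=O)c2ccccc21` gives > 100000 nM in this assay, again a limit.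

All three measured compounds share one core and differ only in the group on the amide-type nitrogen in the ring and in the chain on the pyrazole-type nitrogen. None of them gave a number: the limit of > 100000 nM in this assay, at which 3 of the 3 values shown sit. Compound 3 therefore stands where the other two stand, at a limit, with no measured value to rank it.

Compound 4 `Cn1cc(C2=C(c3nn(CCCN4CCCCC4)c4ncccc34)C(=O)N(c3ccc(Cl)cc3)C2=O)c2ccccc21` differs from compound 3 in one place: 4-chlorophenyl in place of pyridin-2-yl on an amide-type nitrogen in a ring. Among the compounds with values here, because every value shown sits at the limit (the limit of > 100000 nM in this assay, at which 3 of the 3 values shown sit), there is no measured step to lean on, and the expectation for compound 4 is no change beyond the scatter. Compound 4 is therefore estimated at 100000 nM, within 30000 nM to 300000 nM, most likely reported once more as a limit. The expected step of a number no higher from compound 3 to compound 4 (the limit leaves the size open) is, in short, none.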

Compound 4, half-maximal inhibitory concentration: 28700 nM
For compound 4 the middle estimate is 3.5-fold (0.54 log units) above the measured one; measured number below the stated range.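

Placing 4-chlorophenyl instead of pyridin-2-yl on the amide-type nitrogen in the ring, with the rest of the molecule unchanged, gives the first measured number in this set: in this assay the change produces an at least 3.4-fold lower number from compound 3 to compound 4 (0.54 log units; beyond the scatter). Within the data shown here, the group at this position can therefore move a compound off the limit, which the earlier compounds could not show. The true size of the step stays unknown, since compound 3 has only a limit to offer and such limits dominate the set: the limit of > 100000 nM in this assay, at which 3 of the 4 values shown sit.

This single change removes a ring nitrogen and adds a chlorine together, so the compounds shown cannot say which of the two matters. From the compounds shown here alone, it also remains open how a 4-fluorophenyl or 4-methoxyphenyl group on this nitrogen would compare with 4-chlorophenyl.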